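Acrylonitrile amides: chlorofuran replaced by methylphenyl

A few compounds are considered here, and "the series" means these few. Any claim that something is new, unique, unknown or untested is made for them only; others in the source may bear on it.

Compound 1 `N#C/C(=C\c1c(F)c(F)c(F)c(F)c1F)C(=O)c1ccc[nH]1`: in a functional assay on SJ-G2 cells (Homo sapiens) for inhibition, read by MTT assay, with a stated time of 72 h (on this read-out higher numbers stand for weaker inhibition of growth and lower numbers for stronger inhibition of growth), compound 1 gives 23000 nM.
Compound 2 `COc1ccc(CNC(=O)/C(C#N)=C/c2ccc(Cl)o2)cc1`: in this assay compound 2 gives 13000 nM.
Compound 3 `COc1ccc(CNC(=O)/C(C#N)=C/c2ccc(-c3ccccc3)o2)cc1`: in this assay compound 3 reaches only the assay limit, > 100000 nM.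

Compound 2 holds the lowest of the two numbers, though compound 1 sits within the scatter of it, so no order between them is claimed. Compound 4 `COc1ccc(CNC(=O)/C(C#N)=C/c2ccc(C)cc2)cc1` differs from compound 2 by 4-methylphenyl in place of 5-chlorofuran-2-yl on a double-bonded chain carbon bound to a double-bonded chain carbon. Within the data shown here, no measured step matches this exchange of the whole ring. Among the measured compounds shown here, the only step on this end of the chain, an at least 7.6-fold higher number from compound 2 to compound 3 (0.88 log units; beyond the scatter), ends at the limit (the limit of > 100000 nM in this assay, at which 1 of the 3 values shown sits), which shows that enlarging this ring is poorly tolerated. A six-membered carbon ring with a methyl group is a smaller change than adding a phenyl, so a rise of moderate size, a 2.7-fold higher number from compound 2 to compound 4 (0.43 log units; beyond the scatter), is expected, with a real chance of a limit. Compound 4 is estimated at 35000 nM, between 9000 nM and 100000 nM.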

Compound 4, concentration for 50% growth inhibition: 39000 nM
Beside the measured number, compound 4's estimate is 1.1-fold (0.05 log units) below it, and the stated range covers the measured number.
By their numbers in this assay, from the lowest: compounds 2, 1 and 4 (each within the scatter of the next, the first and the last beyond it). At a limit, above all of these: compound 3.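

In this assay, exchanging the whole 5-chlorofuran-2-yl ring for 4-methylphenyl gives a 3.0-fold higher number from compound 2 to compound 4 (0.48 log units; beyond the scatter), a modest loss. This place on the chain therefore accepts a six-membered aromatic ring of carbon only, and a furan ring is not required for a measurable number. Compound 3 remains the only compound at a limit: the limit of > 100000 nM in this assay, at which 1 of the 4 values shown sits.

On these data alone, whether the step comes from the ring itself or from methyl in place of chloro remains open. A 4-chlorophenyl or 5-methylfuran-2-yl group at this place would separate the two.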